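Lengthening the Chain on an Unsubstituted Core

The compounds below may be only part of what the source reports. "The series", "measured", "known", "first", "only" and "open" are said of these compounds alone.

In an assay on HEK293 cells for inhibition of acid ceramidase (Rattus norvegicus), read by LC-MS, with a stated time of 30 min (a lower number here means a stronger inhibitor, a higher number a weaker inhibitor), compound 1 `CCCCCCNC(=O)n1cc(F)c(=O)n(C)c1=O` gives 13 nM. Compound 2 `CCCCCCNC(=O)n1cc(F)c(=O)n(CC)c1=O` carries methyl in place of hydrogen on a saturated chain carbon bound to an aromatic nitrogen and in this assay gives 18 nM; the step is a 1.4-fold higher number from compound 1 to compound 2 (0.14 log units; within the scatter). Compound 3 `CCCCNC(=O)n1ccc(=O)[nH]c1=O` rests on a different core, and the difference between the two cores is not broken down here. In this assay compound 3 gives 8500 nM, the highest number of the three. Compound 4 `CCCCCNC(=O)n1ccc(=O)[nH]c1=O` differs from compound 3 by methyl in place of hydrogen on a saturated chain carbon, four bonds along the chain from an amide-type nitrogen. Among the compounds with values here, this is the same kind of change as the one from compound 1 to compound 2, but the place differs: there the entering methyl sits on a saturated chain carbon bound to an aromatic nitrogen, here on a saturated chain carbon four bonds along the chain from an amide-type nitrogen. The step from compound 3 to compound 4 is expected to be a 2.1-fold lower number from compound 3 to compound 4 (0.33 log units; beyond the scatter), resting on the earlier step of a 1.4-fold higher number from compound 1 to compound 2 (0.14 log units; within the scatter) and on compound 1 with its longer hexyl chain giving 13 nM. Compound 4 is expected to give 4000 nM in this assay, between 1500 nM and 12000 nM.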

Compound 4, half-maximal inhibitory concentration: 2100 nM
Estimate against measurement, compound 4: 1.9-fold (0.28 log units) above, within the range that was stated.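

In this assay, the added methyl gives a 4.0-fold lower number from compound 3 to compound 4 (0.61 log units; beyond the scatter). Set beside the earlier methyl step, this kind of change does not carry over at the same size from one core to the other: the same change on two cores in this assay, a 1.4-fold higher number (0.14 log units; within the scatter) from compound 1 to compound 2 and a 4.0-fold lower number (0.61 log units; beyond the scatter) from compound 3 to compound 4, 5.6-fold (0.75 log units) apart, beyond the scatter of two such steps. Within the data shown here, this gap does not show that the core alone sets the size of the step: the methyl enters at a different place in each pair, and each core offers only this one step.

The compounds shown leave open whether a still longer chain on the core of compound 3 would give a lower number again. They also leave open how a chain ending in an amine or a carboxylic acid would behave on either core.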